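A few compounds are considered here, and "the series" means these few. Any claim that something is new, unique, unknown or untested is made for them only; others in the source may bear on it.

Compound 1 `NS(=O)(=O)Oc1ccc2c(c1)CN(C(=O)c1cccc(N3CCC(Cc4ccccc4)CC3)c1)CC2` gives 1.4% in an assay on HEK293 cells for inhibition of Steryl-sulfatase (Homo sapiens), tested at 0.1 uM; a lower number here means a weaker effect, a higher number a stronger effect of the compound at the concentration tested. Compound 2 `CN(CCCN1CCCCC1)c1ccc(C(=O)N2CCc3ccc(OS(N)(=O)=O)cc3C2)cc1` gives 17.4%. Compound 3 `NS(=O)(=O)Oc1ccc2c(c1)CN(C(=O)c1cccc(N3CCC(N4CCCCC4)CC3)c1)CC2` gives 0%.

Compound 2 stands highest of the three in this assay, beyond the scatter from both compound 1 and compound 3. Compound 4 `CCCN(CCC)c1ccc(C(=O)N2CCc3ccc(OS(N)(=O)=O)cc3C2)cc1` differs from compound 2 by dipropylamino in place of methyl(3-(piperidin-1-yl)propyl)amino on an aromatic carbon. No measured step bears on this change: the only step shown, a number 1.4 percentage points lower from compound 1 to compound 3 (within the scatter), alters a group on a saturated ring carbon elsewhere in the molecule and lies within the scatter, while compounds 1 and 3 differ from compound 2 in more than one place. Lacking a guide, the account expects a modest downward step of a number 8.4 percentage points lower from compound 2 to compound 4 (within the scatter), which may yet fall within the scatter. Compound 4 is therefore estimated at 9%, with a range from 0% to 22%.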

Compound 4, a percentage reported as inhibition, at one concentration (the size of the read-out at that concentration, not a potency): 36.6%
Beside the measured number, compound 4's estimate is 27.6 percentage points below it; measured number above the stated range.
By their numbers in this assay, from the lowest: compounds 3 and 1 (each within the scatter of the next); then compound 2; then compound 4.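

In this assay, dipropylamino in place of methyl(3-(piperidin-1-yl)propyl)amino on an aromatic carbon, para to a large group, gives a number 19.2 percentage points higher from compound 2 to compound 4 (beyond the scatter). This shows that the group at this position matters to the read-out, and that neither the piperidine ring nor the second nitrogen of the leaving group is needed for the higher number. No measurement given here explains the rise.

Going by these compounds alone, the single change removes the ring, the nitrogen and the methyl group together, so their separate shares remain unresolved. On these data alone, how dipropylamino compares with dimethylamino, a longer dialkylamine or morpholine at this position also stays open.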